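Iodothiophene Chalcone: Expected Cytotoxicity From Three Neighbours

The source may hold more compounds than are shown below. What is called first, only, known or untested is meant among the compounds shown, and "the series" means these compounds.

Measured so far:
compound 1 `Cc1ccsc1C(=O)/C=C/c1ccc(N2CCCCC2)cc1`, 63900 nM
compound 2 `Cc1ccc(C(=O)/C=C/c2ccc(N3CCCCC3)cc2)s1`, 50500 nM
compound 3 `O=C(/C=C/c1ccc(N2CCCCC2)cc1)c1cc(Cl)sc1Cl`, 24900 nM

In an ADME assay on Vero cells (Chlorocebus sabaeus) for cytotoxicity, with a stated time of 5 days (on this read-out higher numbers stand for weaker inhibition and lower numbers for stronger inhibition), compound 1 gives the highest of the three numbers. Compound 2 sits nearest, a 1.3-fold lower number from compound 1 to compound 2 (0.10 log units; within the scatter), while compound 3 lies furthest, a 2.6-fold lower number from compound 1 to compound 3 (0.41 log units; beyond the scatter). Compound 4 `O=C(/C=C/c1ccc(N2CCCCC2)cc1)c1ccc(I)s1` differs from compound 1 by 5-iodothiophen-2-yl in place of 3-methylthiophen-2-yl on a carbonyl carbon. For the measured compounds named here, two steps bear on this: the methyl shift a 1.3-fold lower number from compound 1 to compound 2 (0.10 log units; within the scatter) changed little, whereas the halogenated ring a 2.6-fold lower number from compound 1 to compound 3 (0.41 log units; beyond the scatter), echoed by a 2.0-fold lower number from compound 2 to compound 3 (0.31 log units; beyond the scatter), gave a modest lower number. Since compound 4 also carries a halogen on the thiophene, a modest step toward lower numbers is expected, a 1.6-fold lower number from compound 1 to compound 4 (0.20 log units; within the scatter). Compound 4 is therefore estimated at 40000 nM in this assay, within 20000 nM to 80000 nM.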

Compound 4, half-maximal inhibitory concentration: 56500 nM
The estimate for compound 4 lay 1.4-fold (0.15 log units) below the measured number; the range from low to high includes it.
By their numbers in this assay, from the lowest: compound 3; then compounds 2, 4 and 1 (each within the scatter of the next).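

In this assay, iodo in place of methyl on an aromatic carbon leaves the number within the scatter (a 1.1-fold higher number from compound 2 to compound 4 (0.05 log units; within the scatter)), as does 5-iodothiophen-2-yl in place of 3-methylthiophen-2-yl (a 1.1-fold lower number from compound 1 to compound 4 (0.05 log units; within the scatter)). A single iodo on the thiophene therefore does not reproduce the result of compound 3, and the step to the dichlorinated ring lies beyond the scatter (a 2.3-fold higher number from compound 3 to compound 4 (0.36 log units; beyond the scatter)). No evidence explains these steps. The compounds shown leave open where 5-chlorothiophen-2-yl on the carbonyl carbon would fall. They also do not separate halogen type, halogen count and ring attachment.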